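Dropping the acyl group from an anilide chalcone

The source may hold more compounds than are shown below. What is called first, only, known or untested is meant among the compounds shown, and "the series" means these compounds.

Measured compounds:
compound 1 `COc1cc(/C=C/C(=O)c2cccc(NC(=O)c3cc(Cl)cc(Cl)c3)c2)ccc1O`: 51%
compound 2 `COc1cc(/C=C/C(=O)c2cccc(NC(=O)c3ccc(Cl)cc3)c2)ccc1O`: 42%

Of the compounds shown here, two share one core and have been measured in a functional assay on HUVEC cells (Homo sapiens) for inhibition, tested at 5 ug/mL; on this read-out higher numbers stand for a stronger effect at the one concentration tested and lower numbers for a weaker effect. In this assay compound 1 gives 51%, and compound 2 gives 42%. Compound 2 holds the lower of the two numbers, but the step of a number 9 percentage points lower from compound 1 to compound 2 (within the scatter) lies within the scatter, so the two compounds cannot be told apart on this read-out.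

Compound 3 `COc1cc(/C=C/C(=O)c2cccc(N)c2)ccc1O` has not yet been measured. It differs from compound 2 by hydrogen in place of (4-chlorophenyl)carbonyl on a nitrogen on an aromatic ring. Among the compounds with values here, no measured step bears on this change: the only step at hand, a number 9 percentage points lower from compound 1 to compound 2 (within the scatter), swaps one chloro-substituted aryl for another on the carbonyl carbon and leaves the amide in place. The expectation for compound 3 therefore rests on compound 2 alone, with wide uncertainty; a step of a number 12 percentage points lower from compound 2 to compound 3 (beyond the scatter) is expected. Compound 3 is estimated at 30%, within 5% to 60%.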

Compound 3, a percentage reported as inhibition, at one concentration (the size of the read-out at that concentration, not a potency): 50%
The estimate for compound 3 lay 20 percentage points below the measured number; the measured number falls inside the stated range.
By their numbers in this assay, from the lowest: compounds 2, 3 and 1 (each within the scatter of the next).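

In this assay, taking the acyl group off the nitrogen gives a number 8 percentage points higher from compound 2 to compound 3 (within the scatter), and the same removal from the dichloro anilide gives a number 1 percentage points lower from compound 1 to compound 3 (within the scatter). The earlier step only exchanged one chloro-substituted aryl for another with the amide kept, whereas these two steps show that the free amine on the aromatic ring cannot be told apart from either anilide on this read-out, so neither the whole (4-chlorophenyl)carbonyl nor the whole (3,5-dichlorophenyl)carbonyl is required for a number of this size at the one concentration tested. No measurement at hand accounts for this outcome.

On these data alone, it remains open whether a small acetyl group or a methyl group on that nitrogen would separate from these compounds beyond the scatter. A single concentration also leaves open whether the three compounds differ in potency.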